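A few compounds are considered here, and "the series" means these few. Any claim that something is new, unique, unknown or untested is made for them only; others in the source may bear on it.

Measured so far in a functional assay on the whole organism for inhibition of sodium-dependent dopamine transporter (Mus musculus); on this read-out lower numbers stand for an effect already at smaller amounts and higher numbers for an effect only at larger amounts of compound:
compound 1 `CN1Cc2c(N)cccc2C(c2ccc(Cl)cc2)C1` gives 1.5 mg/kg
compound 2 `CCOC(=O)Nc1cccc2c1CN(C)CC2c1ccc(Cl)cc1` gives 21 mg/kg
compound 3 `CCCCNCC(=O)Nc1cccc2c1CN(C)CC2c1ccccc1` gives 25 mg/kg

Compound 3 holds the highest number of the three in this assay; its nearest neighbour is compound 2, whose value sits within the scatter of it, while compound 1 lies furthest away, beyond the scatter. Going by the values given here, the single step that differs in one place, a 14-fold higher number from compound 1 to compound 2 (1.15 log units; beyond the scatter), concerns the group on the ring nitrogen, not the pendant ring, so it does not bear on the change considered here.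

Compound 4 `CCCCNCC(=O)Nc1cccc2c1CN(C)CC2c1ccc(Cl)cc1` differs from compound 3 by chloro in place of hydrogen on an aromatic carbon. Compound 2 carries this chloro and compound 3 does not, and their values in this assay fall within the scatter of each other, but the two also differ at the nitrogen substituent, so nothing clean can be read from that pair. Among the compounds with values here, no measured step isolates the chloro. The expectation for compound 4 is therefore a step of no size beyond the scatter, a 1.3-fold lower number from compound 3 to compound 4 (0.10 log units; within the scatter). Compound 4 is estimated at 20 mg/kg, with a range from 7 mg/kg to 55 mg/kg.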

Compound 4, dose for half-maximal effect: 22 mg/kg
Beside the measured number, compound 4's estimate is 1.1-fold (0.04 log units) below it; measured number inside the range.
By their numbers in this assay, from the lowest: compound 1; then compounds 2, 4 and 3 (each within the scatter of the next).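

In this assay, phenyl to 4-chlorophenyl is now read in isolation, and chloro in place of hydrogen gives a 1.1-fold lower number from compound 3 to compound 4 (0.06 log units; within the scatter), so this change does not separate the pair when the ((butylamino)methyl)carbonyl group is present. With the chloro held constant, (butylamino)methyl in place of ethoxy on the carbonyl carbon gives a 1.0-fold higher number from compound 2 to compound 4 (0.02 log units; within the scatter), while a 15-fold higher number from compound 1 to compound 4 (1.17 log units; beyond the scatter) shows a large step for this acyl group, as a 14-fold higher number from compound 1 to compound 2 (1.15 log units; beyond the scatter) does for ethoxycarbonyl. No measurement at hand accounts for the size of these steps.

Still open, as far as these compounds go, is whether chloro in place of hydrogen reads the same with the free amine of compound 1. Also open, from the compounds shown here alone, is what a fluoro or methoxy group at this place, or a chain longer than butyl on the amine, would do.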